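This account rests on a few compounds, and the source may have more. Where it says the series, first, only, none or still open, it means among the compounds named here.

Working notes on the series. Compound 1 `CCC(=O)N1CCC(CN(C2Cc3cc(C#N)ccc3N(Cc3cncn3C)C2)S(=O)(=O)c2ccccn2)CC1` is the anchor: in an ADME assay on Caco-2 cells (Homo sapiens) for permeability, in the apical to basolateral direction (a lower number here means that the compound crosses the layer more slowly, a higher number that the compound crosses the layer faster), compound 1 gives 0.5 10^-6 cm/s. Its two measured neighbours change only the group on the carbonyl carbon of the piperidine amide. Compound 2 `C=C(C)C(=O)N1CCC(CN(C2Cc3cc(C#N)ccc3N(Cc3cncn3C)C2)S(=O)(=O)c2ccccn2)CC1` gives 0.5 10^-6 cm/s and compound 3 `Cn1cncc1CN1CC(N(CC2CCN(C(=O)c3ccco3)CC2)S(=O)(=O)c2ccccn2)Cc2cc(C#N)ccc21` gives 0.5 10^-6 cm/s, so compound 1 sits level with both, with no change at the digits printed from compound 1 to compound 2 (within the scatter), no change at the digits printed from compound 1 to compound 3 (within the scatter) and no change at the digits printed from compound 2 to compound 3 (within the scatter). Compound 4 `CC(C)OC(=O)N1CCC(CN(C2Cc3cc(C#N)ccc3N(Cc3cncn3C)C2)S(=O)(=O)c2ccccn2)CC1` takes the same position in a new direction: isopropoxy in place of ethyl on a carbonyl carbon. The three steps measured at this carbonyl carbon all lie within the scatter, so no shift beyond the scatter is expected here either, that is no change at the digits printed from compound 1 to compound 4 (within the scatter). Compound 4 is therefore estimated at 0.5 10^-6 cm/s, with a range from 0.3 10^-6 cm/s to 1 10^-6 cm/s.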

Compound 4, apparent permeability: 1 10^-6 cm/s
Beside the measured number, compound 4's estimate is 2.0-fold (0.30 log units) below it, and the stated range covers the measured number.
By their numbers in this assay, from the lowest: compounds 1, 2, 3 and 4 (each within the scatter of the next).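

For the compounds shown here, at this carbonyl carbon, isopropoxy, which brings an oxygen and a hydrogen-bond acceptor that ethyl lacks, is the first group to give a difference at the digits printed in this assay: a 2.0-fold higher number from compound 1 to compound 4 (0.30 log units; within the scatter) and a 2.0-fold higher number from compound 2 to compound 4 (0.30 log units; within the scatter) and a 2.0-fold higher number from compound 3 to compound 4 (0.30 log units; within the scatter) all remain within the scatter. Across ethyl, 1-methylethenyl, furan-2-yl and isopropoxy, this position therefore shows no step beyond the scatter. Nothing measured here gives a reason for these steps. As far as these compounds go, whether an amine or a carboxylic acid on this carbonyl carbon would give a step beyond the scatter stays open, as does the effect of any change elsewhere on the shared core.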